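This account rests on a few compounds, and the source may have more. Where it says the series, first, only, none or still open, it means among the compounds named here.

Measured so far in a physicochemical assay for lipophilicity, at pH 7.4; a lower number here means a more polar compound, a higher number a more lipophilic compound:
- compound 1 `C[C@H]1C[C@@H](c2ccncc2NC(=O)c2nc(-c3ncccc3F)ccc2N)C[C@@H](O)[C@@]1(O)CF` at 1.8
- compound 2 `CC[C@]1(O)[C@H](O)C[C@H](c2ccncc2NC(=O)c2nc(-c3ncccc3F)ccc2N)C[C@@H]1C` at 3.2

Compound 2 holds the higher of the two numbers, and its gap to the other compound is beyond the scatter. The next compound, compound 3 `C[C@H]1C[C@@H](c2ccncc2NC(=O)c2nc(-c3ncccc3F)ccc2N)C[C@@H](O)[C@]1(C)O`, follows from compound 2 by one change: hydrogen in place of methyl on a saturated chain carbon bound to a saturated ring carbon. Going by the values given here, no measured step covers this exact change. Among the compounds with values here, the only step at this kind of place is a number 1.40 log units higher from compound 1 to compound 2 (beyond the scatter), a large one, but it exchanges fluoro for methyl. A fall in this assay is expected, smaller than that step yet probably beyond the scatter. The expected change is a number 0.50 log units lower from compound 2 to compound 3 (beyond the scatter). For compound 3 the estimated value is 2.7, with an expected range of 2.3 to 3.1.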

Compound 3, distribution coefficient: 2.3
Compound 3: middle estimate off by 0.40 log units, on the high side, within the range that was stated.
By their numbers in this assay, from the lowest: compound 1; then compound 3; then compound 2.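

Working notes on the series: in this assay this place on a saturated chain carbon bound to a saturated ring carbon now carries fluoro, hydrogen or methyl on an otherwise unchanged compound. Hydrogen in place of methyl gives a number 0.90 log units lower from compound 2 to compound 3 (beyond the scatter) and is a modest step, and hydrogen in place of fluoro gives a number 0.50 log units higher from compound 1 to compound 3 (beyond the scatter) and is also modest. The earlier large step of a number 1.40 log units higher from compound 1 to compound 2 (beyond the scatter) thus resolves into two parts, each beyond the scatter, with compound 3 lying between the other two. Nothing available explains this order.

As far as these compounds go, whether a longer chain such as propyl would extend the order remains open. So does the standing of an amine or a carboxylic acid at this place.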